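A Larger Side Chain Enters a Series of Low Numbers

The source may report more compounds than this note shows. Statements on the series, on what has been measured and on what is new or still open speak of the compounds shown alone.

Compound 1, `CCCOc1cc(=O)oc2cc(OCc3cccc(F)c3)ccc12`, in an assay on isolated protein (strain Sprague-Dawley) for inhibition of Amine oxidase [flavin-containing] A (Rattus norvegicus), read by spectrophotometry, with a stated time of 5 min, tested at 10 uM; a lower number here means less inhibition, a higher number more inhibition at the concentration tested (going by the name of the read-out): 12%
Compound 2, `CCOc1cc(=O)oc2cc(OCc3cccc(Cl)c3)ccc12`, in this assay: 2%
Compound 3, `CCOc1cc(=O)oc2cc(OCc3cccc(Br)c3)ccc12`, in this assay: 2.5%

Compound 2 gives the lowest of the three numbers. Its nearest neighbour is compound 3, with a step of a number 0.5 percentage points higher from compound 2 to compound 3 (within the scatter); the gap to compound 1 is the largest of the three but is also within the scatter, so none of the three numbers can be called higher or lower than another.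

Compound 4, `O=C(COc1cc(=O)oc2cc(OCc3cccc(Cl)c3)ccc12)N1CCCCC1`, differs from compound 2 in one place: (piperidin-1-yl)carbonyl in place of methyl on a saturated chain carbon bound to an oxygen on an aromatic ring. Among the compounds with values here, the only measured step, a number 0.5 percentage points higher from compound 2 to compound 3 (within the scatter), concerns a halogen swap on an aromatic carbon and says nothing about a change on the saturated chain carbon bound to an oxygen on an aromatic ring. Within the data shown here, no measured step therefore bears on this change, and the expectation rests on compound 2 alone. The step of a number 6 percentage points higher from compound 2 to compound 4 (within the scatter) is expected to stay within the scatter, with a wide range to reflect the missing evidence. Compound 4 is thus estimated to give 8%, between 0% and 30%.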

Compound 4, a percentage reported as inhibition, at one concentration (the size of the read-out at that concentration, not a potency): 9%
Estimate against measurement, compound 4: 1 percentage points below, and the stated range covers the measured number.
By their numbers in this assay, from the lowest: compounds 2, 3, 4 and 1 (each within the scatter of the next).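

Putting (piperidin-1-yl)carbonyl in place of methyl on the saturated chain carbon bound to an oxygen on an aromatic ring is a much bigger change than the halogen swap seen so far, since it brings in a six-membered non-aromatic ring and a hydrogen-bond acceptor. In this assay, this gives a number 7 percentage points higher from compound 2 to compound 4 (within the scatter), so even a group of this size shows no measurable change in inhibition at the concentration tested. No measurement shown here offers an explanation for this result.

Going by these compounds, a carboxylic acid, an amine or a longer chain in place of ((piperidin-1-yl)carbonyl)methyl remains open, and any of these might or might not move the number beyond the scatter. On these data alone, it also remains open whether the same change would give a similar result with bromo in place of chloro on the aromatic carbon.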